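Chloro to Trifluoromethyl: Expected Effect on Seizure Protection

The source may report more compounds than this note shows. Statements on the series, on what has been measured and on what is new or still open speak of the compounds shown alone.

Of the compounds shown here, three sharing one core have been tested in a functional assay on the whole organism (strain Swiss) with Mus musculus as the target, in the maximal electroshock model, with a stated time of 1 h, at a dose of 300 mg/kg by the intraperitoneal route; on this read-out higher numbers stand for a stronger effect at the one dose given and lower numbers for a weaker effect. Compound 1 `CC(C(=O)N1CCN(c2ccccc2)CC1)N1C(=O)CCC1=O` gives 50%, compound 3 `CC(C(=O)N1CCN(c2ccccc2F)CC1)N1C(=O)CCC1=O` gives 50%, and compound 2 `CC(C(=O)N1CCN(c2ccc(Cl)cc2)CC1)N1C(=O)CCC1=O` gives 0%, the lowest of the three. Introducing chloro went with a loss: a number 50 percentage points lower from compound 1 to compound 2 (beyond the scatter). Exchanging the chlorine-bearing ring for the fluorine-bearing ring went with a recovery: a number 50 percentage points higher from compound 2 to compound 3 (beyond the scatter), whereas no change at the digits printed from compound 1 to compound 3 (within the scatter). Compound 4 `CC(C(=O)N1CCN(c2ccc(C(F)(F)F)cc2)CC1)N1C(=O)CCC1=O` differs from compound 2 by trifluoromethyl in place of chloro on an aromatic carbon, on an aromatic carbon para to a large group. For the measured compounds named here, no measured step compares trifluoromethyl with chloro, so the guidance is indirect: the only compound carrying a group at this place, compound 2, showed no activity. Only a modest rise is expected, a number 25 percentage points higher from compound 2 to compound 4 (beyond the scatter), giving compound 4 an estimated 25% within 0% to 75%.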

Compound 4, a percentage reported as activity, at one dose (the size of the read-out at that dose, not a potency): 0%
Compound 4: middle estimate off by 25 percentage points, on the high side; the range from low to high includes it.
By their numbers in this assay, from the lowest: compounds 2 and 4 (each within the scatter of the next); then compounds 1 and 3 (each within the scatter of the next).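

In this assay, trifluoromethyl on this aromatic carbon gives the same outcome as chloro, with no change at the digits printed from compound 2 to compound 4 (within the scatter), while the comparison with the unsubstituted ring shows a number 50 percentage points lower from compound 1 to compound 4 (beyond the scatter). The loss first seen with compound 2 is therefore not confined to chloro, since two different groups at this place now go with it. No available measurement gives a reason for this loss. Going by these compounds, it remains open whether a methyl group or an amine on the same carbon would match compound 2 and compound 4 or instead match compound 1.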